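This account rests on a few compounds, and the source may have more. Where it says the series, first, only, none or still open, it means among the compounds named here.

Going by the values given here, in a functional assay on NCI-H520 cells (Homo sapiens) for inhibition, read by MTT assay, with a stated time of 48 h, tested at 10 uM (on this read-out lower numbers stand for less inhibition and higher numbers for more inhibition at the one concentration tested (going by the name of the read-out)), compound 1 , with structure `COc1cc(NC(=O)Nc2cc(Nc3ccc(C(C)(C)C)cc3)ncn2)cc(OC)c1`, gives 17.5%, the lower of the two numbers known here. Among the compounds with values here, compound 2 , `Cc1ccc(Nc2cc(NC(=O)Nc3c(Cl)cccc3Cl)ncn2)cc1F`, gives 33.5%, which lies beyond the scatter above the number for compound 1 , but the two structures differ in more than one place, so no single step joins them. Compound 3 , `CCc1ccc(Nc2cc(NC(=O)Nc3cc(OC)cc(OC)c3)ncn2)cc1`, is compound 1 with ethyl in place of tert-butyl on an aromatic carbon. Within the data shown here, no measured pair shows what this swap does, so the expected step of a number 1.5 percentage points higher from compound 1 to compound 3 (within the scatter) is small, within the scatter, with no firm direction. Compound 3 is therefore expected to give about 19%, between 5% and 36%.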

Compound 3, a percentage reported as inhibition, at one concentration (the size of the read-out at that concentration, not a potency): 23.5%
Compound 3: middle estimate off by 4.5 percentage points, on the low side; the measured number falls inside the stated range.
By their numbers in this assay, from the lowest: compounds 1, 3 and 2 (each within the scatter of the next, the first and the last beyond it).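

In this assay, the first single-place comparison gives a number 6 percentage points higher from compound 1 to compound 3 (within the scatter). At this position on an aromatic carbon, going from tert-butyl, with 4 heavy atoms, to ethyl, with 2, therefore leaves the read-out within the usual scatter. No outside measurement helps explain this result. As far as these compounds go, whether an amine, a carboxylic acid or a longer chain at this position would shift the number beyond the scatter remains open. So does whether the same swap would behave alike with a different group on the urea.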